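Amine variation at the benzylic position: expected behaviour of compound 4

A few compounds are considered here, and "the series" means these few. Any claim that something is new, unique, unknown or untested is made for them only; others in the source may bear on it.

Measured in an assay on isolated protein for inhibition of Amine oxidase [flavin-containing] B (Homo sapiens), read by fluorescence, with a stated time of 30 min; a lower number here means a stronger inhibitor, a higher number a weaker inhibitor:
compound 1 `COC(=O)C(C)c1ccc(-c2ccc(C(=O)/C=C/c3ccc(CN4CCCCC4)c(O)c3)cc2)c(F)c1` gives 430 nM
compound 2 `COC(=O)C(C)c1ccc(-c2ccc(C(=O)/C=C/c3ccc(CN4CCCC4)c(O)c3)cc2)c(F)c1` gives 430 nM
compound 3 `COC(=O)C(C)c1ccc(-c2ccc(C(=O)/C=C/c3ccc(CN(C)C)c(O)c3)cc2)c(F)c1` gives 430 nM

The three measured compounds share one core and differ only in the amine on a saturated chain carbon bound to an aromatic carbon. Compound 3 stands level with compounds 1 and 2 on the numbers shown: the step of no change at the digits printed from compound 1 to compound 2 (within the scatter), the step of no change at the digits printed from compound 1 to compound 3 (within the scatter) and the step of no change at the digits printed from compound 2 to compound 3 (within the scatter) are all within the scatter, so no ordering among the three can be read from these values.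

Compound 4 `CCN1CCN(Cc2ccc(/C=C/C(=O)c3ccc(-c4ccc(C(C)C(=O)OC)cc4F)cc3)cc2O)CC1` continues this variation. The change from compound 3 is 4-ethylpiperazin-1-yl in place of dimethylamino on a saturated chain carbon bound to an aromatic carbon. All three measured steps bear on it, since each exchanges one amine for another at the same place, and each was flat. On that basis the step from compound 3 to compound 4 in this assay is expected to be no change at the digits printed from compound 3 to compound 4 (within the scatter), with no movement beyond the scatter in either direction anticipated. Compound 4 is therefore estimated at 430 nM, with a range from 200 nM to 950 nM.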

Compound 4, half-maximal inhibitory concentration: 430 nM
Beside the measured number, compound 4's estimate shows no gap at the digits printed, and the stated range covers the measured number.
By their numbers in this assay, from the lowest: compounds 1, 2, 3 and 4 (each within the scatter of the next).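

In this assay, the exchange of dimethylamino for 4-ethylpiperazin-1-yl on a saturated chain carbon bound to an aromatic carbon gives no change at the digits printed from compound 3 to compound 4 (within the scatter), although the group grows from 3 to 8 heavy atoms and gains a six-membered non-aromatic ring with 2 hetero atoms. The comparisons with the two smaller ring amines read the same, with no change at the digits printed from compound 2 to compound 4 (within the scatter) and no change at the digits printed from compound 1 to compound 4 (within the scatter), so the flat result at this position now extends from amines with one nitrogen to a ring with two nitrogens carrying an ethyl group. Nothing available explains why the four amines do not separate in this assay.

The compounds shown leave open whether this tolerance extends to a group of another type at the same place, such as a carboxylic acid, a primary amide or a simple hydroxyl in place of the amine. They also leave open whether a longer chain between the aromatic carbon and the amine, or a bulkier substituent such as benzyl on the piperazine ring, would still leave the number level with the others.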